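Replacing an Aromatic Group on an Amine Nitrogen

The source may hold more compounds than are shown below. What is called first, only, known or untested is meant among the compounds shown, and "the series" means these compounds.

Compound 1 `CC(C)=CCc1cc(C(=O)Nc2cc3ccc(OCCCN[C@H](C)c4ccccc4)c(C)c3oc2=O)ccc1O`: 1000 nM
Compound 2 `CC(C)=CCc1cc(C(=O)Nc2cc3ccc(OCCCNC(C)(C)c4ccccc4)c(C)c3oc2=O)ccc1O`: 960 nM

Both values come from a functional assay on SK-BR-3 cells (Homo sapiens) for antiproliferative activity; on this read-out lower numbers stand for stronger inhibition and higher numbers for weaker inhibition. Within the data shown here, with only two numbers so far, compound 2 cannot be told apart from compound 1, so the pair marks a single level of activity rather than a ranking. The next structure, compound 3 `CC(C)=CCc1cc(C(=O)Nc2cc3ccc(OCCCN[C@@H]4C[C@H]5CC[C@@H]4C5)c(C)c3oc2=O)ccc1O`, keeps the core of compound 2 and alters only the group on the amine nitrogen: a group of 7 heavy atoms (7 carbon; 2 five-membered non-aromatic rings of carbon only) in place of a group of 9 heavy atoms (9 carbon; one six-membered aromatic ring of carbon only), on an amine nitrogen.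

Among the measured compounds shown here, only one measured step bears on this change. In a 1.0-fold lower number from compound 1 to compound 2 (0.02 log units; within the scatter), 1-methyl-1-phenylethyl replaces 1-phenylethyl, and the size of that step lies within the scatter. That step is a useful but limited guide, since both groups carry the aromatic ring. For the measured compounds named here, no measured compound shows what happens when that ring is absent, so the range must stay wide. No shift beyond the scatter is expected in this assay, and the estimated step is a 1.0-fold higher number from compound 2 to compound 3 (0.02 log units; within the scatter). For compound 3, the expected value is 1000 nM, with an estimated range of 300 nM to 3000 nM.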

Compound 3, half-maximal inhibitory concentration: 770 nM
Compound 3: middle estimate off by 1.3-fold (0.11 log units), on the high side, within the range that was stated.
By their numbers in this assay, from the lowest: compounds 3, 2 and 1 (each within the scatter of the next).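

The earlier pair only exchanged one group carrying an aromatic ring for another, whereas here that ring is gone from the group on the amine nitrogen, and this assay shows a 1.2-fold lower number from compound 2 to compound 3 (0.10 log units; within the scatter). Measured against the other aromatic group, the outcome is the same, with a 1.3-fold lower number from compound 1 to compound 3 (0.11 log units; within the scatter). All three compounds therefore sit at one level of activity, so among these compounds an aromatic ring on this nitrogen is not needed to hold that level. Nothing available here explains why the non-aromatic carbon group and the two aromatic groups match.

Still open, on these data alone, is how small or how different this group can become: a plain methyl or cyclopropyl on the nitrogen, or a group carrying a hydroxyl or a carboxylic acid, could give a clearly different number. Also open, as far as these compounds go, are the other stereoisomers of the group in compound 3, since it has 3 defined stereocentres, and whether a longer chain leading to the amine nitrogen would leave this level of activity unchanged.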